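The source may hold more compounds than are shown below. What is called first, only, known or untested is meant among the compounds shown, and "the series" means these compounds.

Compound 1 `CN(C)c1ccc(/C=C/c2c(F)cccc2Cl)cc1` and compound 2 `CN(C)c1ccc(/C=C/c2c(Cl)cccc2Cl)cc1` share one core and differ in a single place. In a functional assay on LS174T cells (Homo sapiens) for antiproliferative activity (on this read-out higher numbers stand for weaker inhibition and lower numbers for stronger inhibition), compound 1 gives 19.2 nM, whereas compound 2 gives 214 nM. The change between them is chloro in place of fluoro on an aromatic carbon, and it made an 11-fold higher number from compound 1 to compound 2 (1.05 log units; beyond the scatter). Compound 3 `CN(C)c1ccc(/C=C/c2c(F)cccc2Cl)nc1` is built on another core; the difference between the two cores is not broken down here. In this assay compound 3 gives 20.4 nM, which lies within the usual scatter of the number for compound 1. Compound 4 `CN(C)c1ccc(/C=C/c2c(Cl)cccc2Cl)nc1` remains to be measured in this assay. It differs from compound 3 by chloro in place of fluoro on an aromatic carbon, the same change that separates compound 1 and compound 2, at the same place on the ring. Among the compounds with values here, since the only step of this kind seen so far is an 11-fold higher number from compound 1 to compound 2 (1.05 log units; beyond the scatter), the step from compound 3 to compound 4 is expected to be of a similar size, namely an 11-fold higher number from compound 3 to compound 4 (1.03 log units; beyond the scatter). On that basis compound 4 is expected to give 220 nM in this assay, with a likely range from 100 nM to 480 nM.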

Compound 4, half-maximal inhibitory concentration: 59.5 nM
Compound 4: middle estimate off by 3.7-fold (0.57 log units), on the high side, and the stated range ends above it.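

On the core of compound 3, chloro in place of fluoro on an aromatic carbon gives a 2.9-fold higher number from compound 3 to compound 4 (0.46 log units; beyond the scatter) in this assay and so runs in the same direction as on the core of compound 1. The direction carried over between the two cores, but the size did not: the same change on two cores in this assay, an 11-fold higher number (1.05 log units; beyond the scatter) from compound 1 to compound 2 and a 2.9-fold higher number (0.46 log units; beyond the scatter) from compound 3 to compound 4, 3.8-fold (0.58 log units) apart, beyond the scatter of two such steps. With one pair on each core, this shows that the size of the step depended on the core in these four compounds, but it does not show why, and it does not tell how the change would behave on a further core.

The compounds shown leave open whether other groups on this aromatic carbon, such as bromo, methyl, methoxy or nitrile, would also give steps that differ between the two cores. They also leave open whether the direction seen here would hold for any of those groups.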